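The compounds below may be only part of what the source reports. "The series", "measured", "known", "first", "only" and "open" are said of these compounds alone.

Compound 1 `CC1(C)[N+]([O-])=c2ccc(COc3cccc(C=O)c3)cc2=[N+]1[O-]`: < 50 uM
Compound 2 `NC(=S)N/N=C\c1ccccc1OCc1ccc2no[n+]([O-])c2c1`: 189 uM

Both compounds were tested in an ADME assay on cells (Erythrocyte, Homo sapiens), read by spectrophotometry and hemolysis, with a stated time of 24 h; on this read-out higher numbers stand for weaker inhibition and lower numbers for stronger inhibition. Compound 1 is known there only through a limit of the assay, < 50 uM, and not through a number. Compound 2 gives a true number, 189 uM.

Compound 3 `CC1(C)[N+]([O-])=c2ccc(COc3cccc(/C=N/NC(N)=S)c3)cc2=[N+]1[O-]` has not yet been measured. It keeps the core of compound 1 but loses the formyl, and a group with no common name enters in its place, on an aromatic carbon of a six-membered aromatic ring of carbon only, meta to a large group: a group of 6 heavy atoms (2 carbon, 3 nitrogen, 1 sulfur; no ring) in place of a group of 2 heavy atoms (1 carbon, 1 oxygen; no ring), on an aromatic carbon.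

Within the data shown here, no measured pair isolates this change, so the expectation is loose. It leans on compound 2 at 189 uM, which carries a similar chain on a different core. A shift toward higher numbers, beyond the usual scatter, is expected, though the limit on compound 1 leaves its size uncertain. The estimated change is an at least 2.2-fold higher number from compound 1 to compound 3 (0.34 log units; beyond the scatter). For compound 3 the expected value is 110 uM, with an estimated range of 35 uM to 300 uM.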

Compound 3, concentration for 50% inhibition: 141 uM
The estimate for compound 3 lay 1.3-fold (0.11 log units) below the measured number; low and high end bracket the measured number.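

In this assay, putting the group of 6 heavy atoms in place of the formyl, on an aromatic carbon of a six-membered aromatic ring of carbon only, meta to a large group, gives an at least 2.8-fold higher number from compound 1 to compound 3 (0.45 log units; beyond the scatter). Among these compounds, until now no measured pair isolated this change, whereas this one shows a shift beyond the scatter on the core of compound 1 itself, with only that one place differing. The step gives a lower bound and not a full size, because compound 1 is known only through a limit of the assay: the limit of < 50 uM in this assay, at which 1 of the 3 values shown sits.

The compounds shown leave open which part of the entering group goes with the higher number, as the same chain with oxygen in place of its sulfur, or a simple amine or carboxylic acid in place of the formyl, would be needed to separate its parts. They also leave open whether a longer chain at this place would move the number further, and how large the step is once compound 1 has a true value.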